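The source may hold more compounds than are shown below. What is called first, only, known or untested is meant among the compounds shown, and "the series" means these compounds.

Of the compounds shown here, two in this set have been tested for antiproliferative activity. Compound 1 `C=CS(=O)(=O)N1CCN(c2ccn3ncc(-c4ccccc4)c3n2)CC1` gives 19500 nM in a functional assay on MDA-MB-436 cells (Homo sapiens) for antiproliferative activity, read by MTT assay, with a stated time of 48 h; on this read-out lower numbers stand for stronger inhibition and higher numbers for weaker inhibition. Compound 2 `CN1CCN(c2ccc(-c3cc4c(N5CCN(C(=O)Nc6ccccc6)CC5)ncnc4s3)cc2)CC1` gives 7090 nM in this assay, which places compound 2 as the lower of the two numbers, with compound 1 standing beyond the scatter above it. Among the measured compounds shown here, no single-point step between measured compounds is available, so there is no measured precedent for the change that leads to compound 3 `CN1CCN(c2ccc(-c3cc4c(N5CCN(C(=O)Nc6cc(C(F)(F)F)ccc6F)CC5)ncnc4s3)cc2)CC1`. Compound 3 differs from compound 2 in one place, (2-fluoro-5-(trifluoromethyl)phenyl in place of phenyl on an amide-type nitrogen). In the absence of a measured precedent, the step from compound 2 to compound 3 is expected to be a modest one toward a lower number, of size a 2.0-fold lower number from compound 2 to compound 3 (0.31 log units; beyond the scatter), though a result within the scatter cannot be excluded. Compound 3 is therefore estimated at 3500 nM in this assay, with a range from 1000 nM to 12000 nM.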

Compound 3, half-maximal inhibitory concentration: 8840 nM
Estimate against measurement, compound 3: 2.5-fold (0.40 log units) below; low and high end bracket the measured number.
By their numbers in this assay, from the lowest: compounds 2 and 3 (each within the scatter of the next); then compound 1.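

Among the compounds shown here, the change to 2-fluoro-5-(trifluoromethyl)phenyl in place of phenyl on the amide-type nitrogen in this assay gives a 1.2-fold higher number from compound 2 to compound 3 (0.10 log units; within the scatter) and is the first comparison in the set that turns on a single place. It shows that, at this place, the aromatic ring can carry a fluorine and a trifluoromethyl group together without moving the number beyond the scatter. Nothing measured here bears on the reason for this outcome.

Since both substituents enter at once, these compounds cannot separate what the fluorine and the trifluoromethyl group each contribute, alone or in combination. Also open, as far as these compounds go, is how this place would respond to a carboxylic acid or an amine on the ring, or to a cyclohexyl group or a longer alkyl chain in place of the ring.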